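The compounds below may be only part of what the source reports. "The series", "measured", "known", "first", "only" and "open" are said of these compounds alone.

In a functional assay on the whole organism (strain albino) for inhibition, with Rattus norvegicus as the target, read by paw edema, with stated times of 1 h and 0.5 h, at a dose of 100 mg/kg by the oral route (on this read-out higher numbers stand for more inhibition at the one dose given (going by the name of the read-out) and lower numbers for less inhibition), three compounds have been measured. Compound 1 `O=C(CSc1nc(-c2ccc(Cl)cc2)c(C(=O)O)c(=O)[nH]1)Nn1c(COc2ccc(Cl)cc2Cl)nc2ccccc2c1=O` gives 51.9%. Compound 2 `N#Cc1c(Cl)nc(SCC(=O)Nn2c(COc3ccc(Cl)cc3Cl)nc3ccccc3c2=O)nc1-c1ccccc1` gives 53.9%, and compound 3 `N#Cc1c(Cl)nc(SCC(=O)Nn2c(COc3ccc(Cl)cc3Cl)nc3ccccc3c2=O)nc1-c1ccc(Cl)cc1` gives 61.5%, the highest of the three numbers, although its distance from each of the other two stays within the scatter of this assay. Going by the values given here, the only measured step that alters a single place, a number 7.6 percentage points higher from compound 2 to compound 3 (within the scatter), is likewise within the scatter. Compound 4 `N#Cc1c(Cl)nc(SCC(=O)Nn2c(COc3ccc(Cl)cc3Cl)nc3ccccc3c2=O)nc1-c1ccc(O)cc1` has not yet been measured; it differs from compound 3 by hydroxy in place of chloro on an aromatic carbon. The step from compound 2 to compound 3 concerns the same aromatic carbon as this change. There the exchange moved the number only within the scatter. Among the compounds with values here, no measured pair shows a hydroxy entering anywhere. The account therefore expects in this assay a step no larger than the scatter, with no firm direction. Compound 4 is expected to give 56%, within a range from 44% to 68%. The implied step, a number 5.5 percentage points lower from compound 3 to compound 4 (within the scatter), is expected to remain within the scatter.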

Compound 4, a percentage reported as inhibition, in the whole organism at one dose (the size of the read-out at that dose, not a potency): 67.3%
Beside the measured number, compound 4's estimate is 11.3 percentage points below it; the range from low to high includes it.
By their numbers in this assay, from the lowest: compounds 1, 2, 3 and 4 (each within the scatter of the next, the first and the last beyond it).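

In this assay, the exchange of 4-chlorophenyl for 4-hydroxyphenyl gives a number 5.8 percentage points higher from compound 3 to compound 4 (within the scatter), so this read-out does not separate chloro from hydroxy on this aromatic carbon. Hydroxy in place of hydrogen at the same place gives a number 13.4 percentage points higher from compound 2 to compound 4 (beyond the scatter), the first single change among these compounds to lie beyond the scatter, though only modestly. Chloro in place of hydrogen there had given only a number 7.6 percentage points higher from compound 2 to compound 3 (within the scatter), so this position is now seen to respond to a substituent, at least to hydroxy.

The compounds shown leave open what a methoxy, an amine or a longer alkoxy chain would give on this carbon. They also leave open whether hydroxy in place of hydrogen would give a similar step on another core. Nothing available explains the step to compound 4.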